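Permeability of an anilide series: a pyridyl amide next

The compounds below may be only part of what the source reports. "The series", "measured", "known", "first", "only" and "open" are said of these compounds alone.

Three amides of one shared aniline core have been measured in an ADME assay for permeability, using PAMPA; on this read-out higher numbers stand for higher permeability and lower numbers for lower permeability. Compound 1 `C/C=C/C(=O)Nc1cccc(-c2nc3ccccc3s2)c1` gives 1640 10^-6 cm/s, compound 2 `C=C(C)C(=O)Nc1cccc(-c2nc3ccccc3s2)c1` gives 987 10^-6 cm/s, and compound 3 `O=C(CCl)Nc1cccc(-c2nc3ccccc3s2)c1` gives 660 10^-6 cm/s. Compound 3 thus holds the lowest of the three numbers; its step to compound 2 is within the scatter, while a 2.5-fold lower number from compound 1 to compound 3 (0.40 log units; beyond the scatter).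

The unmeasured compound 4 `O=C(Nc1cccc(-c2nc3ccccc3s2)c1)c1ccncc1Cl` differs from compound 3 in one place: 3-chloropyridin-4-yl in place of chloromethyl on a carbonyl carbon. Going by the values given here, the steps that bear on this change are those that alter the same carbonyl substituent: a 1.7-fold lower number from compound 1 to compound 2 (0.22 log units; within the scatter), a 2.5-fold lower number from compound 1 to compound 3 (0.40 log units; beyond the scatter) and a 1.5-fold lower number from compound 2 to compound 3 (0.17 log units; within the scatter). All three variations at this position move this assay by small amounts, at most modestly beyond the scatter, and each replacement that reduced the group's carbon chain left the number lower. Among the compounds with values here, the change to compound 4 is larger in its counted atoms than any of those steps, so a somewhat greater movement cannot be ruled out, yet nothing among the measured compounds points to a large one.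

For compound 4 the expected step is therefore a 1.5-fold lower number from compound 3 to compound 4 (0.17 log units; within the scatter), a mild decrease that may still lie within the scatter. Compound 4 is estimated to give 450 10^-6 cm/s in this assay, in a range from 200 10^-6 cm/s to 950 10^-6 cm/s.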

Compound 4, apparent permeability: 563 10^-6 cm/s
Beside the measured number, compound 4's estimate is 1.3-fold (0.10 log units) below it; the range from low to high includes it.
By their numbers in this assay, from the lowest: compounds 4, 3, 2 and 1 (each within the scatter of the next, the first and the last beyond it).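

In this assay, the position on the carbonyl carbon accepts a much larger group with no step beyond the scatter (a 1.2-fold lower number from compound 3 to compound 4 (0.07 log units; within the scatter)), even though 3-chloropyridin-4-yl brings 7 heavy atoms, one six-membered aromatic ring and 1 hydrogen-bond acceptor where chloromethyl had 2 heavy atoms, no ring and no acceptor. Compound 4 also stands towards the other two amides as compound 3 does, within the scatter of the 1-methylethenyl amide (a 1.8-fold lower number from compound 2 to compound 4 (0.24 log units; within the scatter)) and beyond it only from the prop-1-en-1-yl amide, in a modest step (a 2.9-fold lower number from compound 1 to compound 4 (0.46 log units; beyond the scatter)), so the first aromatic ring at this position leaves the span of the series little changed. No measurement shown here gives a reason for this result.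

With a single ring-bearing amide in the set, the shares of the ring nitrogen and the ring chlorine remain unseparated, and plain phenyl or unsubstituted pyridin-4-yl would be needed to tell them apart. From the compounds shown here alone, it also stays open how this read-out would respond at this position to an aminomethyl group, a carboxylic acid or a longer alkyl chain.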